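Hydrogen for Phenyl on the Ring Nitrogen: Compound 4

This account rests on a few compounds, and the source may have more. Where it says the series, first, only, none or still open, it means among the compounds named here.

Compound 1 `Cc1ccc(C2=NN(c3ccc([N+](=O)[O-])cc3)C(c3cn(-c4ccccc4)nc3-c3ccc(Cl)c(Cl)c3)C2)cc1`: 57.4%
Compound 2 `Fc1ccc(C2=NN(c3ccccc3)C(c3cn(-c4ccccc4)nc3-c3ccc(Cl)c(Cl)c3)C2)cc1`: 44.7%
Compound 3 `Clc1ccc(C2=NN(c3ccccc3)C(c3cn(-c4ccccc4)nc3-c3ccc(Cl)c(Cl)c3)C2)cc1`: 45.7%

In a functional assay on the whole organism (strain Wistar) for inhibition, with Rattus norvegicus as the target, read by paw edema, with a stated time of 30 min, at a dose of 50 mg/kg by the oral route (a lower number here means less inhibition, a higher number more inhibition at the dose given (going by the name of the read-out)), compound 2 gives 44.7%, the lowest of the three numbers shown. Compound 3 is nearest, a number 1 percentage points higher from compound 2 to compound 3 (within the scatter), the change being chloro in place of fluoro on an aromatic carbon. For the measured compounds named here, compound 1 stands furthest from compound 2; compound 1 gives 57.4%, a gap beyond the scatter, but compound 1 differs from compound 2 in more than one place, so the two values show only that gap and no single step.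

Compound 4 `Fc1ccc(C2=NNC(c3cn(-c4ccccc4)nc3-c3ccc(Cl)c(Cl)c3)C2)cc1` has not been measured. It differs from compound 2 by hydrogen in place of phenyl on an amine nitrogen in a ring. Going by the values given here, no measured step bears on a change on an amine nitrogen in a ring: the only measured step, a number 1 percentage points higher from compound 2 to compound 3 (within the scatter), changes a group on an aromatic carbon and lies within the scatter. The expectation for compound 4 therefore rests on the value of compound 2 alone, with a wide range. Compound 4 is expected to give 38%, with a range from 24% to 52%. The expected step is a number 6.7 percentage points lower from compound 2 to compound 4 (within the scatter), a small downward move that may well fall within the scatter.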

Compound 4, a percentage reported as inhibition, in the whole organism at one dose (the size of the read-out at that dose, not a potency): 45.7%
Compound 4: middle estimate off by 7.7 percentage points, on the low side; measured number inside the range.
By their numbers in this assay, from the lowest: compounds 2, 3 and 4 (each within the scatter of the next); then compound 1.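

In this assay, hydrogen in place of phenyl on an amine nitrogen in a ring gives a number 1 percentage points higher from compound 2 to compound 4 (within the scatter) and so shows that, at this single oral dose, the phenyl with its 6 heavy atoms can leave this place without the read-out moving beyond the scatter. For the compounds shown here, the earlier step concerned only a group on an aromatic carbon, so this is the first change at the ring nitrogen to be read one place at a time, and it shows that the level of inhibition seen with compound 2 does not depend on having phenyl there. Nothing measured here accounts for this result, and the data offer no reason for it.

Against this, compound 1 gives 57.4% with a nitrophenyl on the ring nitrogen, but it also differs elsewhere, so its number cannot be assigned to that nitrogen alone. Open too, on these data alone, is how a methyl, an acetyl or a carboxylic acid-bearing chain would read on this nitrogen, and whether hydrogen there would leave the read-out equally level in the chloro analogue, compound 3.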